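Dropping the Iodo Group: From Compound 1 to Compound 3

A few compounds are considered here, and "the series" means these few. Any claim that something is new, unique, unknown or untested is made for them only; others in the source may bear on it.

Measured compounds:
compound 1, `O=C1C=C(Nc2ccc(I)cc2)C(=O)c2c1nc1n2[C@H]2OC[C@@H](O)[C@H]2OC1`: 2230 nM
compound 2, `CCOc1ccc(NC2=CC(=O)c3c(nc4n3[C@H]3OC[C@@H](O)[C@H]3OC4)C2=O)cc1`: > 4000 nM

Both compounds were tested in a functional assay on MCF7 cells (Homo sapiens) for inhibition, read by sulforhodamine B assay; on this read-out lower numbers stand for stronger inhibition and higher numbers for weaker inhibition. For the measured compounds named here, compound 1 gives 2230 nM, the only actual number among the two results. For compound 2 the result is > 4000 nM, which is a limit of the assay and not a number (the limit of > 4000 nM in this assay, at which 1 of the 2 values shown sits). Going by the values given here, compound 1 therefore stands as the single compound with a true measured value in this assay.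

Compound 3, `O=C1C=C(Nc2ccccc2)C(=O)c2c1nc1n2[C@H]2OC[C@@H](O)[C@H]2OC1`, has not yet been measured. It differs from compound 1 in one place: hydrogen in place of iodo on an aromatic carbon. Among the compounds with values here, because no step between two measured compounds is available here, the effect of this change in this assay cannot be read off and must be expected instead. Taking the iodo group away and leaving only a hydrogen on that aromatic carbon is expected to weaken inhibition to a modest degree, and the expected step is a 1.6-fold higher number from compound 1 to compound 3 (0.20 log units; within the scatter). Compound 3 is accordingly estimated at 3500 nM, with a range from 1200 nM to 10000 nM.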

Compound 3, half-maximal inhibitory concentration: > 4000 nM
Compound 3: a limit, no number; the forecaster's own chance of this, stated with the estimate: 40%; at least 1.1-fold (0.05 log units) between middle value and limit.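

With 4-iodophenyl changed to phenyl, compound 3 gives > 4000 nM in this assay, a limit of the assay and not a number. For the compounds shown here, this is the first change at this place on the aromatic ring whose effect can be read at all, and it can be stated only as a floor, an at least 1.7-fold higher number from compound 1 to compound 3 (0.25 log units; that floor lies within the scatter), so the real difference may be small or much larger. The step cannot be narrowed further, and compound 1 remains the only compound here with a true number, because the read-out ends at the same point for the other two: the limit of > 4000 nM in this assay, at which 2 of the 3 values shown sit.

From the compounds shown here alone, what stays open is how much of the inhibition seen with compound 1 depends on the iodo group itself, since the true value of compound 3 lies somewhere beyond the limit and the floor does not separate it from compound 1 by more than the usual scatter. The compounds shown also leave open what other groups on that aromatic carbon would give, such as chloro, an amine or a carboxylic acid, and whether any of them would bring the result back to a measurable number.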